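The source may report more compounds than this note shows. Statements on the series, on what has been measured and on what is new or still open speak of the compounds shown alone.

Measured in a functional assay on PC-3 cells (Homo sapiens) for cytotoxicity, read by sulforhodamine B assay, with a stated time of 48 h; a lower number here means a stronger inhibitor, a higher number a weaker inhibitor:
- compound 1 `C[C@H]1CC[C@@H]2[C@@H](OC(=O)[C@]23CC(c2ccccc2Br)=NO3)[C@]2(C)C(=O)C=C[C@@]12O`: 51000 nM
- compound 2 `C[C@H]1CC[C@@H]2[C@@H](OC(=O)[C@]23CC(c2ccccc2F)=NO3)[C@]2(C)C(=O)C=C[C@@]12O`: 8200 nM

Compound 2, at 8200 nM, holds the lower of the two numbers. Compound 3 `C[C@H]1CC[C@@H]2[C@@H](OC(=O)[C@]23CC(c2ccc(C#N)cc2)=NO3)[C@]2(C)C(=O)C=C[C@@]12O` has 4-cyanophenyl in place of 2-fluorophenyl on a carbon with a double bond to nitrogen. Within the data shown here, only one measured step bears on this change: a 6.2-fold lower number from compound 1 to compound 2 (0.79 log units; beyond the scatter), a modest step beyond the scatter. It involves a swap on the same aromatic group but does not show how a nitrile will behave. A modest rise is expected in this assay, with an estimated 2.4-fold higher number from compound 2 to compound 3 (0.39 log units; beyond the scatter). For compound 3 the expected value is 20000 nM, with an estimated range of 6000 nM to 70000 nM.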

Compound 3, half-maximal inhibitory concentration: 32000 nM
Compound 3: middle estimate off by 1.6-fold (0.20 log units), on the low side; low and high end bracket the measured number.
By their numbers in this assay, from the lowest: compound 2; then compounds 3 and 1 (each within the scatter of the next).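

In this assay, 4-cyanophenyl in place of 2-fluorophenyl gives a 3.9-fold higher number from compound 2 to compound 3 (0.59 log units; beyond the scatter), so compound 2 keeps the lowest number of the three. 4-cyanophenyl in place of 2-bromophenyl gives a 1.6-fold lower number from compound 1 to compound 3 (0.20 log units; within the scatter), so these two groups are not separated here. Nothing available explains either result. Compound 3 differs from compound 2 in both the group on the aromatic ring and its ring position, so the two effects cannot be separated. From the compounds shown here alone, how 2-cyanophenyl, 4-fluorophenyl, or an aromatic ring bearing an amine or a carboxylic acid would behave remains open.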